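The compounds below may be only part of what the source reports. "The series", "measured", "known", "first", "only" and "open" are said of these compounds alone.

Measured compounds:
- compound 1 `Cc1ccc2nc(C)n(NC(=O)/C(C#N)=C/c3ccccc3)c(=O)c2c1`: 9000 nM
- compound 2 `Cc1ccc2nc(C)n(NC(=O)/C(C#N)=C/c3ccc([N+](=O)[O-])cc3)c(=O)c2c1`: 12000 nM
- compound 3 `Cc1ccc2nc(C)n(NC(=O)/C(C#N)=C/c3cccc(O)c3)c(=O)c2c1`: 15000 nM

These three compounds share one core and differ only in the aryl group on the double-bonded chain carbon. In a functional assay on MCF7 cells (Homo sapiens) for cytotoxicity, read by MTT assay, with a stated time of 3 days (on this read-out higher numbers stand for weaker inhibition and lower numbers for stronger inhibition), compound 3 gives 15000 nM, the highest of the three numbers, yet its nearest neighbour is compound 2 at a 1.3-fold higher number from compound 2 to compound 3 (0.10 log units; within the scatter) and the further one is compound 1 at a 1.7-fold higher number from compound 1 to compound 3 (0.22 log units; within the scatter); neither separation is beyond the scatter, so no order among the three can be claimed.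

Compound 4 `Cc1ccc2nc(C)n(NC(=O)/C(C#N)=C/c3ccc(O)cc3)c(=O)c2c1` has not yet been measured. It differs from compound 3 by 4-hydroxyphenyl in place of 3-hydroxyphenyl on a double-bonded chain carbon bound to a double-bonded chain carbon. Among the measured compounds shown here, two measured steps bear on this: the exchange of one aryl group for another at the same place, a 1.3-fold higher number from compound 2 to compound 3 (0.10 log units; within the scatter), and the introduction of a hydroxy group onto the aryl ring, a 1.7-fold higher number from compound 1 to compound 3 (0.22 log units; within the scatter). Both stayed within the scatter. Moving the hydroxy group around the same ring is therefore expected to give no step beyond the scatter, a 1.3-fold lower number from compound 3 to compound 4 (0.10 log units; within the scatter). Compound 4 is estimated at 12000 nM, within a range from 5000 nM to 30000 nM.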

Compound 4, half-maximal inhibitory concentration: 14000 nM
Compound 4: the middle estimate sits 1.2-fold (0.07 log units) below what was measured, within the range that was stated.
By their numbers in this assay, from the lowest: compounds 1, 2, 4 and 3 (each within the scatter of the next).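

In this assay, among the compounds shown here, the change of 3-hydroxyphenyl to 4-hydroxyphenyl on a double-bonded chain carbon bound to a double-bonded chain carbon gives a 1.1-fold lower number from compound 3 to compound 4 (0.03 log units; within the scatter) and so adds something the earlier compounds did not show: relocating the hydroxy group on the same ring, not only adding or exchanging a group, also stays within the scatter. Compound 4 also cannot be separated from the other two, with a 1.2-fold higher number from compound 2 to compound 4 (0.07 log units; within the scatter) for hydroxy in place of nitro and a 1.6-fold higher number from compound 1 to compound 4 (0.19 log units; within the scatter) for hydroxy in place of hydrogen, so the four aryl groups shown cannot be ranked. No measurement is available to explain why these numbers lie so close.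

The compounds shown leave open whether an amine, a carboxylic acid or a methoxy group on this ring would give a step beyond the scatter. They also leave open whether a longer chain in place of the aryl group, or a change to the shared core, would do so.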